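Compound 3 and the bromo-to-methyl step

The source may report more compounds than this note shows. Statements on the series, on what has been measured and on what is new or still open speak of the compounds shown alone.

In a functional assay on LOX IMVI cells (Homo sapiens) for cytotoxicity, read by MTT assay, with a stated time of 24 h (a higher number here means a weaker inhibitor, a lower number a stronger inhibitor), compound 1 (`COc1cc(-c2nc(-c3ccccc3)[nH]c2-c2ccnc(NCCCNS(=O)(=O)c3ccc(Br)cc3)n2)ccc1F`) gives 33900 nM and compound 3 (`COc1cc(-c2nc(-c3ccccc3)[nH]c2-c2ccnc(NCCCNS(=O)(=O)c3ccc(Br)cc3)n2)ccc1Cl`) gives 23700 nM. Chloro in place of fluoro on an aromatic carbon accounts for a 1.4-fold lower number from compound 1 to compound 3 (0.16 log units; within the scatter), so these two compounds cannot be told apart in this assay. Compound 2 (`COc1cc(-c2nc(-c3ccccc3)[nH]c2-c2ccnc(NCCCNS(=O)(=O)c3ccc(C)cc3)n2)ccc1F`) gives 2590 nM, the lowest number of the three, and compound 3 stands well above it.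

Compound 4 (`COc1cc(-c2nc(-c3ccccc3)[nH]c2-c2ccnc(NCCCNS(=O)(=O)c3ccc(C)cc3)n2)ccc1Cl`) follows from compound 3 by placing methyl in place of bromo on an aromatic carbon, para to a large group: methyl in place of bromo on an aromatic carbon. The same change, 4-bromophenyl to 4-methylphenyl, has been measured once, and it gave a 13-fold lower number from compound 1 to compound 2 (1.12 log units; beyond the scatter), a large step. The chloro-for-fluoro step, a 1.4-fold lower number from compound 1 to compound 3 (0.16 log units; within the scatter), suggests that the fluoro and chloro series may run alike, but a single pair offers only limited support for carrying the large step across. A step in the same direction, beyond the scatter and perhaps slightly smaller, is therefore expected, and the expected size is a 10-fold lower number from compound 3 to compound 4 (1.01 log units; beyond the scatter). For compound 4 the estimated value is 2300 nM, with an expected range from 800 nM to 7000 nM.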

Compound 4, half-maximal inhibitory concentration: 18600 nM
For compound 4 the middle estimate is 8.1-fold (0.91 log units) below the measured one; measured number above the stated range.
By their numbers in this assay, from the lowest: compound 2; then compounds 4, 3 and 1 (each within the scatter of the next).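

With the chloro core, methyl in place of bromo gives only a 1.3-fold lower number from compound 3 to compound 4 (0.11 log units; within the scatter) in this assay, so the large step seen on the fluoro core does not carry over, and the effect of this change depends on which halogen the core holds: the same change on two cores in this assay, a 13-fold lower number (1.12 log units; beyond the scatter) from compound 1 to compound 2 and a 1.3-fold lower number (0.11 log units; within the scatter) from compound 3 to compound 4, 10-fold (1.01 log units) apart, beyond the scatter of two such steps. The reverse reading holds for the halogen: chloro in place of fluoro, which could not be told apart with the 4-bromophenyl group, gives a 7.2-fold higher number from compound 2 to compound 4 (0.86 log units; beyond the scatter) with the 4-methylphenyl group: the same change on two cores in this assay, a 1.4-fold lower number (0.16 log units; within the scatter) from compound 1 to compound 3 and a 7.2-fold higher number (0.86 log units; beyond the scatter) from compound 2 to compound 4, 10-fold (1.01 log units) apart, beyond the scatter of two such steps. The two changes therefore do not add up in these four compounds: only the pairing of fluoro with 4-methylphenyl, in compound 2, gives a clearly lower number, while compound 4, compound 3 and compound 1 lie each within the scatter of the next.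

Going by these compounds, it remains open whether this dependence on the core extends to other groups on the same aromatic carbon, such as an ethyl or an amine, or to a hydrogen in place of the halogen on the core. For the compounds shown here, with only one pair on each core, it also stays open whether the low number of compound 2 reflects that combination or a single outlying reading.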